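The source may report more compounds than this note shows. Statements on the series, on what has been measured and on what is new or still open speak of the compounds shown alone.

Compound 3 `COc1cccc(OC)c1OCCNCCOc1ccccc1OCc1ccc(Cl)cc1` gives 0.0316 nM in an assay on CHO cells for displacement of a labelled ligand from Alpha-1D adrenergic receptor (Homo sapiens) (on this read-out lower numbers stand for stronger inhibition and higher numbers for weaker inhibition), the lowest of the three numbers, though only within the scatter of compound 2 `COc1cccc(OC)c1OCCNCCOc1ccccc1OCc1cccc(Cl)c1`, which gives 0.0501 nM; compound 1 `COc1cccc(OC)c1OCCNCCOc1ccccc1OCc1ccccc1Cl` gives 0.251 nM. Compound 4 `COc1cccc(OC)c1OCCNCCOc1ccccc1OCc1ccccc1C` carries 2-methylphenyl in place of 4-chlorophenyl on a saturated chain carbon bound to an oxygen on an aromatic ring. The measured steps that bear on it are a 7.9-fold lower number from compound 1 to compound 3 (0.90 log units; beyond the scatter) and a 5.0-fold lower number from compound 1 to compound 2 (0.70 log units; beyond the scatter), whereas a 1.6-fold lower number from compound 2 to compound 3 (0.20 log units; within the scatter) stayed within the scatter. Nothing here tests methyl against chlorine, but the 2-methylphenyl of compound 4 resembles the 2-chlorophenyl of compound 1 more than the 4-chlorophenyl of compound 3, so for compound 4 a rise in the number is expected, a 4.7-fold higher number from compound 3 to compound 4 (0.68 log units; beyond the scatter). Compound 4 is estimated at 0.15 nM, with a range from 0.04 nM to 0.6 nM.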

Compound 4, inhibition constant: 0.126 nM
For compound 4 the middle estimate is 1.2-fold (0.08 log units) above the measured one; low and high end bracket the measured number.
By their numbers in this assay, from the lowest: compounds 3 and 2 (each within the scatter of the next); then compounds 4 and 1 (each within the scatter of the next).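

In this assay, the 2-methylphenyl group falls with the 2-chlorophenyl group: methyl in place of chloro on an aromatic carbon gives a 2.0-fold lower number from compound 1 to compound 4 (0.30 log units; within the scatter), so the two cannot be told apart at this position. The 4-chlorophenyl and 3-chlorophenyl groups remain separated from it, with a 4.0-fold higher number from compound 3 to compound 4 (0.60 log units; beyond the scatter) and a 2.5-fold higher number from compound 2 to compound 4 (0.40 log units; beyond the scatter). Nothing available explains these steps. As far as these compounds go, it remains open whether 3-methylphenyl or 4-methylphenyl would track their chlorinated counterparts, and how a methoxyphenyl or pyridyl group would read at this place.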